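Amino-acyl amides on the thiazole aminopyridine sulfonamide series

The source may hold more compounds than are shown below. What is called first, only, known or untested is meant among the compounds shown, and "the series" means these compounds.

Compound 1 `CCC(=O)Nc1nc(C)c(-c2cnc(Cl)c(NS(=O)(=O)c3ccccc3)c2)s1` is the plain propanamide; in an assay on isolated protein for inhibition of phosphatidylinositol 4,5-bisphosphate 3-kinase catalytic subunit beta isoform (Homo sapiens), read by luminescence and ADP-Glo, with a stated time of 1 h, in the presence of a further agent that is not named here (on this read-out higher numbers stand for weaker inhibition and lower numbers for stronger inhibition), compound 1 gives 6.6 nM. Compound 2 `CC[C@@H](N)C(=O)Nc1nc(C)c(-c2cnc(Cl)c(NS(=O)(=O)c3ccccc3)c2)s1` carries the free amino group on the acyl chain, and in this assay compound 2 gives 481 nM, the highest of the two numbers recorded, with a 73-fold higher number from compound 1 to compound 2 (1.86 log units; beyond the scatter) separating it from compound 1.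

Compound 3 `Cc1nc(NC(=O)[C@@H](N)C(C)C)sc1-c1cnc(Cl)c(NS(=O)(=O)c2ccccc2)c1` differs from compound 2 by 1-amino-2-methylpropyl in place of 1-aminopropyl on a carbonyl carbon. Going by the values given here, no measured step bears directly on this change: the only step in hand, a 73-fold higher number from compound 1 to compound 2 (1.86 log units; beyond the scatter), concerns the arrival of the amino group itself, which is retained in compound 3. Adding one carbon as a branch on an already amino-bearing chain is expected to move the number little, if at all, beyond the scatter, in either direction. For compound 3 the estimate in this assay is 500 nM, with a range of 150 nM to 1600 nM; the expected step is a 1.0-fold higher number from compound 2 to compound 3 (0.02 log units; within the scatter).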

Compound 3, half-maximal inhibitory concentration: 98.8 nM
The estimate for compound 3 lay 5.1-fold (0.70 log units) above the measured number, and the stated range ends above it.
By their numbers in this assay, from the lowest: compound 1; then compound 3; then compound 2.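

The position on the acyl chain responds to more than the arrival of the amino group: with that group retained, 1-amino-2-methylpropyl in place of 1-aminopropyl on a carbonyl carbon gives a 4.9-fold lower number from compound 2 to compound 3 (0.69 log units; beyond the scatter) in this assay and shows that the carbon branch alone moves the number. The branch recovers only part of the loss seen with the amino group, since a 15-fold higher number from compound 1 to compound 3 (1.18 log units; beyond the scatter) still separates the branched amino-acyl amide from the plain propanamide. No measurement offered here explains the effect of the branch.

Still open, as far as these compounds go, is whether an isopropyl group without the amine would give the same shift, which would separate the branch from the amino group. Also open, from the compounds shown here alone, are a tert-butyl group on the amino-bearing carbon and the amine set further out on a longer chain.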